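Capping the amine: a methanesulfonamide on the alkyne side chain

A few compounds are considered here, and "the series" means these few. Any claim that something is new, unique, unknown or untested is made for them only; others in the source may bear on it.

Compound 1 `COc1cc[nH]c1/C=C1\C(=O)Nc2ccc(F)c(C#CC(O)CN)c21` gives 110 nM in a functional assay on SW480 cells (Homo sapiens) for inhibition; a higher number here means a weaker inhibitor, a lower number a stronger inhibitor.
Compound 2 `COc1cc[nH]c1/C=C1\C(=O)Nc2ccc(F)c(C#C[C@@H](N)CO)c21` gives 205 nM in this assay.
Compound 3 `COc1cc[nH]c1/C=C1\C(=O)Nc2ccc(F)c(C#C[C@@H](N)[C@@H](C)O)c21` gives 210 nM in this assay.

All three compounds share one core and differ only in the short chain on the triple-bonded carbon. Compound 1 sits at one end of the three numbers, yet both other compounds lie within the scatter of it: the step of a 1.9-fold higher number from compound 1 to compound 2 (0.27 log units; within the scatter) and the step of a 1.9-fold higher number from compound 1 to compound 3 (0.28 log units; within the scatter) are both small, and the step of a 1.0-fold higher number from compound 2 to compound 3 (0.01 log units; within the scatter) is flat. Compound 4 `COc1cc[nH]c1/C=C1\C(=O)Nc2ccc(F)c(C#C[C@@H](NS(C)(=O)=O)[C@@H](C)O)c21` has not been measured. It differs from compound 1 in this way: 2-hydroxy-1-(methanesulfonamido)propyl in place of 2-amino-1-hydroxyethyl on a triple-bonded carbon. Two of the measured steps bear on it, since they rearrange the same chain and add the methyl that compound 4 also carries; none of them covers the methanesulfonamide itself. Given those small steps, a modest weakening beyond the scatter is expected, with wide uncertainty. Compound 4 is therefore estimated at 300 nM, in the range 100 nM to 1000 nM, a step of a 2.7-fold higher number from compound 1 to compound 4 (0.44 log units; beyond the scatter).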

Compound 4, half-maximal inhibitory concentration: 1190 nM
For compound 4 the middle estimate is 4.0-fold (0.60 log units) below the measured one; the measured number lies above the stated range.
By their numbers in this assay, from the lowest: compounds 1, 2 and 3 (each within the scatter of the next); then compound 4.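

Until now, reshaping the chain on the triple-bonded carbon moved the number in this assay only within the scatter, but putting methylsulfonyl on the amine nitrogen gives a clear loss, with a 5.7-fold higher number from compound 3 to compound 4 (0.75 log units; beyond the scatter). The loss is of similar size from the other uncapped compound with the amine on this carbon, with a 5.8-fold higher number from compound 2 to compound 4 (0.76 log units; beyond the scatter), and it is larger still against the best of the three, with an 11-fold higher number from compound 1 to compound 4 (1.03 log units; beyond the scatter). So this position accepted moving the amino and hydroxyl groups and adding a methyl, yet it did not accept this change on the nitrogen, and nothing available here explains the loss.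

An acetyl group or a single methyl on the same nitrogen would show whether any cap costs this much or only methylsulfonyl does. A free carboxylic acid or a longer chain in this place remains an open question too.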